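Clearance notes: chloro to hydroxybutynyl on compound 3

A few compounds are considered here, and "the series" means these few. Any claim that something is new, unique, unknown or untested is made for them only; others in the source may bear on it.

In an ADME assay (liver) for metabolic stability, with Liver microsome (Rattus norvegicus) as the target, using microsomes and NADPH, with a stated time of 30 min, at 37 degrees C, tested at 1 uM (a higher number here means faster removal of the compound, a lower number slower removal), compound 1 `CC(O)(c1ccc(N2CCN(S(=O)(=O)c3ccc(N)nc3)CC2)cc1)C(F)(F)F` gives < 14 mL.min-1.g-1, which is a limit of the assay. Compound 2 `CC(O)(c1ccc(-c2ccc(S(=O)(=O)c3ccc(N)nc3)cn2)nc1)C(F)(F)F` gives < 14 mL.min-1.g-1, again a limit. Within the data shown here, compound 3 `Nc1ccc(S(=O)(=O)c2ccc(-c3ncc(C(O)(C(F)(F)F)C(F)(F)F)cc3Cl)cc2)cn1` gives 18 mL.min-1.g-1, the only true number in this small set. Compound 4 `C[C@H](O)C#Cc1cc(C(O)(C(F)(F)F)C(F)(F)F)cnc1-c1ccc(S(=O)(=O)c2ccc(N)nc2)cc1` carries 3-hydroxybut-1-yn-1-yl in place of chloro on an aromatic carbon. Among the measured compounds shown here, no measured pair in the set shows this change or any other single change, so the expectation rests on weak ground. The expected step of a 1.2-fold higher number from compound 3 to compound 4 (0.09 log units; within the scatter) in this assay is small, slightly upward and not clearly beyond the scatter. For compound 4 the estimate is 22 mL.min-1.g-1, with an expected range of 14 mL.min-1.g-1 to 45 mL.min-1.g-1.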

Compound 4, intrinsic clearance in microsomes: 29 mL.min-1.g-1
Compound 4: middle estimate off by 1.3-fold (0.12 log units), on the low side, and the stated range covers the measured number.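

On this aromatic carbon, ortho to a large group and two atoms from the ring nitrogen, 3-hydroxybut-1-yn-1-yl in place of chloro gives a 1.6-fold higher number from compound 3 to compound 4 (0.21 log units; within the scatter) in this assay. Among these compounds, this is the first single-place change readable, and both compounds carry true numbers rather than limits. The position takes the larger chain, with its hydrogen-bond donor and acceptor, without a step beyond the scatter. As far as these compounds go, what an amine or a carboxylic acid on this carbon would give stays open. The other compounds cannot be placed against this pair by size: the limit of < 14 mL.min-1.g-1 in this assay, at which 2 of the 4 values shown sit.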